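A Methoxy Group Joins the Shared Core of Compound 2

The source may report more compounds than this note shows. Statements on the series, on what has been measured and on what is new or still open speak of the compounds shown alone.

Compound 2 `O=C(/C=C/C=C/c1ccccc1)N1CCCCC1` gives 57.2 ug/mL in a functional assay on A549 cells (Homo sapiens) for cytotoxicity, read by XTT assay, with a stated time of 48 h (on this read-out higher numbers stand for weaker inhibition and lower numbers for stronger inhibition), and compound 1 `CN(C)c1ccc(/C=C/C=C/C(=O)N2CCCCC2)cc1` gives 69.1 ug/mL in this assay, the two numbers standing within the scatter of each other. Compound 3 `COc1ccc(/C=C/C=C/C(=O)N2CCCCC2)cc1` differs from compound 2 by methoxy in place of hydrogen on an aromatic carbon. Among the compounds with values here, the only step that bears on this change is a 1.2-fold lower number from compound 1 to compound 2 (0.08 log units; within the scatter), itself a swap of a group on an aromatic carbon of the shared core. A change of similar size is therefore expected, a 1.0-fold lower number from compound 2 to compound 3 (0.02 log units; within the scatter), with no clear direction beyond the scatter. Compound 3 is estimated at 55 ug/mL, most likely between 30 ug/mL and 100 ug/mL.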

Compound 3, half-maximal inhibitory concentration: 63.2 ug/mL
Compound 3: the middle estimate sits 1.1-fold (0.06 log units) below what was measured; the range from low to high includes it.
By their numbers in this assay, from the lowest: compounds 2, 3 and 1 (each within the scatter of the next).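

Methoxy in place of hydrogen gives a 1.1-fold higher number from compound 2 to compound 3 (0.04 log units; within the scatter) in this assay and methoxy in place of dimethylamino gives a 1.1-fold lower number from compound 1 to compound 3 (0.04 log units; within the scatter) on the same aromatic carbon, para to a large group. This position has now held three groups, hydrogen, methoxy and dimethylamino, and their numbers all stand within the scatter of one another. No measurement at hand offers an explanation for this closeness. On these data alone, whether a carboxylic acid, a chlorine atom or a longer chain on this carbon would move the number beyond the scatter remains open.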